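A few compounds are considered here, and "the series" means these few. Any claim that something is new, unique, unknown or untested is made for them only; others in the source may bear on it.

Notes on the series. Compound 1 `CC(C)(C)c1ccc(C(=O)N2CCC3(CC2)C(=O)N(CC(=O)NCCC(=O)O)CN3c2ccccc2)cc1` has the higher of the two numbers recorded in an assay on HEK293 cells for displacement of a labelled ligand from NPC1-like intracellular cholesterol transporter 1 (Homo sapiens); a higher number here means a weaker inhibitor, a lower number a stronger inhibitor: compound 1 gives 11400 nM. Compound 3 `O=C(CN1CN(c2ccccc2)C2(CCN(C(=O)c3ccc(C4CCCCC4)cc3)CC2)C1=O)N1CCC(CO)CC1` gives 1100 nM in this assay, a gap beyond the scatter. Compound 2 `CC(C)(C)OC(=O)NCCCCNC(=O)CN1CN(c2ccccc2)C2(CCN(C(=O)c3ccc(C(C)(C)C)cc3)CC2)C1=O` has no result in this assay, recorded as "not determined" (no result reported). Compound 4 `CC(C)(C)c1ccc(C(=O)N2CCC3(CC2)C(=O)N(CC(=O)N2CCC(CCO)CC2)CN3c2ccccc2)cc1` is compound 1 with one change: 4-(2-hydroxyethyl)piperidin-1-yl in place of (2-carboxyethyl)amino on a carbonyl carbon. Among the measured compounds shown here, no measured pair carries exactly this change, so the step is judged from the two numbers only; compound 3, which also ends in a piperidinyl amide, gives 1100 nM, so the step is expected to run toward a lower number, beyond the scatter, estimated as a 4.6-fold lower number from compound 1 to compound 4 (0.66 log units; beyond the scatter). For compound 4 the expected value is 2500 nM, within a range from 800 nM to 8000 nM.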

Compound 4, half-maximal inhibitory concentration: 2600 nM
Beside the measured number, compound 4's estimate is 1.0-fold (0.02 log units) below it, and the stated range covers the measured number.
By their numbers in this assay, from the lowest: compound 3; then compound 4; then compound 1.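

Among the compounds shown here, on the carbonyl carbon, 4-(2-hydroxyethyl)piperidin-1-yl in place of (2-carboxyethyl)amino gives the first single-place step: in this assay it is a 4.4-fold lower number from compound 1 to compound 4 (0.64 log units; beyond the scatter) and counts as modest. The carboxyl end of compound 1 is therefore not required for a measurable value at this position. No measurement shown explains the step.

The change adds the piperidine ring and removes the carboxylic acid together, so their separate contributions cannot be read. As far as these compounds go, whether an amine or a longer chain in place of the terminal hydroxyl would shift the number remains open.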